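The source may hold more compounds than are shown below. What is called first, only, known or untested is meant among the compounds shown, and "the series" means these compounds.

Working notes on the series. In a functional assay on B16 cells (Mus musculus) for cytotoxicity, read by MTT assay, with a stated time of 48 h (a lower number here means a stronger inhibitor, a higher number a weaker inhibitor), compound 1 (`C=C1CCC[C@]2(C)CCC(C=O)=CC[C@@]12C`) gives 230000 nM, compound 2 (`C#CC1=CC[C@]2(CC1)C(=C)CC[C@H]2C(C)C`) gives 123000 nM and compound 3 (`C=C1CCC[C@]2(C)CCC(c3cn(-c4ccc(C(C)=O)cc4)nn3)=CC[C@@]12C`) gives 61000 nM. Compound 3 stands within the scatter of compound 2, while compound 1 carries a higher number, beyond the scatter from compound 3.

Compound 4 (`C=C1CCC[C@]2(C)CCC(c3cn(-c4cccc(OC)c4)nn3)=CC[C@@]12C`) has 3-methoxyphenyl in place of 4-acetylphenyl on an aromatic nitrogen of the five-membered aromatic ring with 3 nitrogen: 3-methoxyphenyl in place of 4-acetylphenyl on an aromatic nitrogen. Within the data shown here, no pair of measured compounds differs in one place, so the series offers no direct measure of this exchange. Among the measured compounds shown here, the only anchor is compound 3 at 61000 nM, the one measured compound that also has a substituted phenyl at this place.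

In this assay the expected step, a 1.1-fold higher number from compound 3 to compound 4 (0.03 log units; within the scatter), stays within the scatter, with no firm direction. For compound 4 the estimated value is 65000 nM, with an expected range from 25000 nM to 150000 nM.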

Compound 4, half-maximal inhibitory concentration: 34700 nM
For compound 4 the middle estimate is 1.9-fold (0.27 log units) above the measured one, within the range that was stated.
By their numbers in this assay, from the lowest: compounds 4, 3, 2 and 1 (each within the scatter of the next, the first and the last beyond it).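

The exchange of 4-acetylphenyl for 3-methoxyphenyl on an aromatic nitrogen now has a direct measure: in this assay the step is a 1.8-fold lower number from compound 3 to compound 4 (0.25 log units; within the scatter). At this position the two substituted phenyl groups therefore cannot be told apart in this read-out, although they differ both in the group carried and in where it sits on the phenyl ring. Nothing available explains this similarity.

As far as these compounds go, the step changes the group and its place together, so the contribution of each alone remains open. Also open, from the compounds shown here alone, is whether a phenyl bearing an amine or a carboxylic acid, or a longer alkyl chain in place of the phenyl on this nitrogen, would move the number beyond the scatter.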